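The source may report more compounds than this note shows. Statements on the series, on what has been measured and on what is new or still open speak of the compounds shown alone.

Compound 1 `CC(C)(C)c1nc2ccc(NCc3cccc(C(F)(F)F)c3)cc2n(CCNC(=O)CO)c1=O`: > 3000 nM
Compound 2 `CC1(C)Oc2ccc(NCc3ccc(Cl)c(Cl)c3)cc2N(CCNC(=O)CO)C1=O`: 12 nM

Of the compounds shown here, two have been measured in an assay for inhibition of acyl-CoA desaturase 1 (Rattus norvegicus), using microsomes; on this read-out lower numbers stand for stronger inhibition and higher numbers for weaker inhibition. Compound 2 gives 12 nM in this assay. For compound 1 the read-out in this assay is a limit, > 3000 nM, and not a number. Compound 1 therefore stands at the limit of > 3000 nM in this assay, at which 1 of the 2 values shown sits. Compounds 1 and 2 differ in more than one place, so nothing joins their two values beyond what each shows on its own.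

Compound 3 `CC(C)c1nc2ccc(NCc3cccc(C(F)(F)F)c3)cc2n(CCNC(=O)CO)c1=O` has not yet been measured. It differs from compound 1 in one place: hydrogen in place of methyl on a saturated chain carbon bound to an aromatic carbon and two saturated chain carbons. For the measured compounds named here, no measured pair shows this change, so its size is unknown from these data. With compound 1 at a limit, any step can only be a rough guess. Compound 3 is expected to stay near that limit, the step being estimated as a step that the limit leaves unreadable from compound 1 to compound 3. In this assay compound 3 is estimated at 4000 nM, in the range 1000 nM to 15000 nM, with a good chance that only a limit is reported again.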

Compound 3, half-maximal inhibitory concentration: 2800 nM
Compound 3: middle estimate off by 1.4-fold (0.15 log units), on the high side; the measured number falls inside the stated range.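

For the compounds shown here, at the saturated chain carbon bound to an aromatic carbon and two saturated chain carbons, the isopropyl of compound 3 gives an actual number in this assay, 2800 nM, and so provides the first measured value for this series of substituents at this place. The change from tert-butyl to isopropyl can be read only as an at least 1.0-fold lower number from compound 1 to compound 3 (0.02 log units; that floor lies within the scatter), so the data do not show that losing the methyl moves the read-out at all. The true size of the step stays unknown because one end of it is not a number: the limit of > 3000 nM in this assay, at which 1 of the 3 values shown sits.

The compounds shown leave open how this assay would respond to other groups at this place, such as an ethyl or a cyclopropyl group, which would show whether the read-out here moves with the group at all. Also open, on these data alone, is what separates compound 3 from compound 2, which gives 12 nM, since those two differ in more than one place and no single change links them.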